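Fluoro in Place of Methoxy: What to Expect for Compound 4

The source may hold more compounds than are shown below. What is called first, only, known or untested is meant among the compounds shown, and "the series" means these compounds.

Three compounds have been measured in a functional assay on KB cells (Homo sapiens) for cytotoxicity, read by sulforhodamine B assay; on this read-out lower numbers stand for stronger inhibition and higher numbers for weaker inhibition:
compound 1 `C=C1[C@@H](OC(C)=O)C[C@@H]2[C@](C)(CO[Si](C)(C)C(C)(C)C)[C@H](OC(C)=O)CC[C@@]2(C)[C@@H]1C[C@@H](Nc1ccc(OC)cc1)C1=CCOC1=O`, 5630 nM
compound 2 `C=C1[C@@H](OC(C)=O)C[C@@H]2[C@](C)(CO[Si](C)(C)C(C)(C)C)[C@H](OC(C)=O)CC[C@@]2(C)[C@@H]1C[C@@H](Nc1cccc2ccccc12)C1=CCOC1=O`, 8930 nM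
compound 3 `C=C1[C@@H](OC(C)=O)C[C@@H]2[C@](C)(COC=O)[C@H](OC(C)=O)CC[C@@]2(C)[C@@H]1C[C@@H](Nc1ccc(OC)cc1)C1=CCOC1=O`, 32700 nM

Compound 3 shows the highest number of the three, so it is the weakest inhibitor here; the step of a 5.8-fold higher number from compound 1 to compound 3 (0.76 log units; beyond the scatter) is beyond the scatter. Compound 4 `C=C1[C@@H](OC(C)=O)C[C@@H]2[C@](C)(COC=O)[C@H](OC(C)=O)CC[C@@]2(C)[C@@H]1C[C@@H](Nc1ccc(F)cc1)C1=CCOC1=O` differs from compound 3 only on the aryl group of the amine: fluoro in place of methoxy on an aromatic carbon. Within the data shown here, the only measured step on that aryl group, a 1.6-fold higher number from compound 1 to compound 2 (0.20 log units; within the scatter), stayed within the scatter, and no step with fluoro exists. The expectation is therefore a step of a 1.1-fold higher number from compound 3 to compound 4 (0.03 log units; within the scatter), meaning no change beyond the scatter. Compound 4 is expected to give 35000 nM, within a range of 14000 nM to 85000 nM.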

Compound 4, half-maximal inhibitory concentration: 22900 nM
Compound 4: middle estimate off by 1.5-fold (0.18 log units), on the high side, and the stated range covers the measured number.
By their numbers in this assay, from the lowest: compounds 1 and 2 (each within the scatter of the next); then compounds 4 and 3 (each within the scatter of the next).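

Fluoro in place of methoxy on the aromatic ring gives a 1.4-fold lower number from compound 3 to compound 4 (0.15 log units; within the scatter) in this assay, so this exchange leaves the number within the scatter. Together with a 1.6-fold higher number from compound 1 to compound 2 (0.20 log units; within the scatter), this makes a second change on the aryl group of the amine that stays within the scatter, though on a different version of the core. The data shown offer no explanation for this.

Going by these compounds, whether an amine or a carboxylic acid in the same place on the ring would also leave the number within the scatter stays open. So does whether fluoro would behave alike in a compound that otherwise matches compound 1.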